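Benzyl-to-hydrogen steps in a T47D cytotoxicity series

The source may hold more compounds than are shown below. What is called first, only, known or untested is meant among the compounds shown, and "the series" means these compounds.

Compound 1 `COc1cc(OC)c2cc(-c3ccc(OCc4ccccc4)cc3)c(O)nc2c1`, compound 2 `COc1ccc(-c2cc3c(OC)cc(OC)cc3n(CC(=O)OCc3ccccc3)c2=O)cc1` and compound 3 `COc1ccc(-c2cc3c(OC)cc(OC)cc3n(CC(=O)O)c2=O)cc1` were run in a functional assay on T47D cells (Homo sapiens) for cytotoxicity, read by colorimetric assay and MTT assay; on this read-out higher numbers stand for weaker inhibition and lower numbers for stronger inhibition. Compound 1 gives 10000 nM, compound 2 gives 10000 nM and compound 3 gives 10000 nM. The step of no change at the digits printed from compound 2 to compound 3 (within the scatter) is the change (hydrogen in place of benzyl on an oxygen next to a carbonyl group). How the core of compound 1 differs from that of compound 2 is not broken down here; the two values stand level within the scatter. Compound 4 `COc1cc(OC)c2cc(-c3ccc(O)cc3)c(O)nc2c1` is unmeasured and differs from compound 1 by hydrogen in place of benzyl on an oxygen on an aromatic ring. This is the same kind of change as from compound 2 to compound 3, not the same: there the oxygen sits next to a carbonyl group, here on an aromatic ring. The expected step of no change at the digits printed from compound 1 to compound 4 (within the scatter) is placed beside the earlier one, resting on compound 2 giving 10000 nM and compound 3 giving 10000 nM. Compound 4 is thus estimated at 10000 nM, within 5000 nM to 20000 nM.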

Compound 4, half-maximal inhibitory concentration: 10000 nM
For compound 4 middle estimate and measured number coincide at the digits printed; the measured number falls inside the stated range.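

In this assay, hydrogen in place of benzyl on an oxygen on an aromatic ring gives no change at the digits printed from compound 1 to compound 4 (within the scatter), and the change reads alike on the two cores: the same change on two cores in this assay, no change at the digits printed (within the scatter) from compound 2 to compound 3 and no change at the digits printed (within the scatter) from compound 1 to compound 4, 1.0-fold (0.00 log units) apart, within the scatter of two such steps. So far, the change carries from one core to the other with no visible difference, whether the oxygen sits on an aromatic ring or next to a carbonyl group. This rests on one pair per core, and all four compounds share one printed value, so it shows agreement only at that level and not how the change would read on a compound with a lower number.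

Open, from the compounds shown here alone, is whether an amine or a longer chain in place of benzyl on that oxygen would move the value. Also open, going by these compounds, is whether the step stays the same on a core that gives a lower number.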